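Swapping a cyclic carbonate ester for a trifluoroethyl ester

This account rests on a few compounds, and the source may have more. Where it says the series, first, only, none or still open, it means among the compounds named here.

Compound 1 `Cc1oc(=O)oc1COC(=O)c1cccc(NC(=O)[C@@H]2C[C@H](SC3=C(C(=O)O)N4C(=O)[C@H]([C@@H](C)O)[C@H]4[C@H]3C)CN2)c1` gives > 95% in an ADME assay for metabolic stability, read by LC-MS, with a stated time of 3 h, at pH 6.5, tested at 50 uM (on this read-out lower numbers stand for a less stable compound and higher numbers for a more stable compound), which is a limit of the assay rather than a number.
Compound 2 `Cc1oc(=O)oc1COC(=O)C1=C(S[C@@H]2CN[C@H](C(=O)Nc3cccc(C(=O)OCc4oc(=O)oc4C)c3)C2)[C@H](C)[C@@H]2[C@@H]([C@@H](C)O)C(=O)N12` gives > 95% in this assay, again a limit.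
Compound 3 `C[C@@H](O)[C@H]1C(=O)N2C(C(=O)OCOC(=O)OC3CCCCC3)=C(S[C@@H]3CN[C@H](C(=O)Nc4cccc(C(=O)OCOC(=O)OC5CCCCC5)c4)C3)[C@H](C)[C@H]12` gives > 95% in this assay, also a limit.

Compound 1 thus stands at the upper end of what this assay can report; only a limit, not a number, is known for it. Among the measured compounds shown here, the one measured step between neighbours, a step that the two limits leave unreadable from compound 1 to compound 2, cannot be sized, since both of its compounds sit at the limit of > 95% in this assay, at which 3 of the 3 values shown sit. Compound 4 `C[C@@H](O)[C@H]1C(=O)N2C(C(=O)O)=C(S[C@@H]3CN[C@H](C(=O)Nc4cccc(C(=O)OCC(F)(F)F)c4)C3)[C@H](C)[C@H]12` differs from compound 1 by a group of 4 heavy atoms (1 carbon, 3 fluorine; no ring) in place of a group of 7 heavy atoms (4 carbon, 3 oxygen; one five-membered aromatic ring with 2 hetero atoms), on a saturated chain carbon bound to an oxygen next to a carbonyl group. For the measured compounds named here, no measured step touches this exchange: the step from compound 1 to compound 2 adds a group elsewhere, and compound 3 carries a different ester altogether, so nothing in the measured set tells how the trifluoromethyl group behaves in this assay. With every measured compound at the limit, the plain expectation is that compound 4 also stays near it. Compound 4 is therefore estimated at 92%, within 72% to 99%. The expected step from compound 1 to compound 4 is a number at least 3 percentage points lower from compound 1 to compound 4 (that floor lies within the scatter), which is not beyond the scatter.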

Compound 4, percent of the compound remaining: > 95%
Compound 4: no number, only a limit (the forecaster's own chance of this, stated with the estimate: 55%); middle value at least 3 percentage points away from the limit.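

Compound 4 gives > 95% in this assay, which is a limit and not a number. Compound 1 also sits at a limit, so no step between compound 1 and compound 4 can be read: the limit of > 95% in this assay, at which 4 of the 4 values shown sit.

The compounds shown leave open how stable each one really is, and whether any of these esters would give a readable number in this assay.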